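A few compounds are considered here, and "the series" means these few. Any claim that something is new, unique, unknown or untested is made for them only; others in the source may bear on it.

Compound 1 `NC(=O)/C=C/c1ccncc1-c1ccc2ccccc2c1` carries a 2-carbamoylethenyl group on its core, and in an assay on a protein complex for inhibition of CDK8/Cyclin C (Homo sapiens), with a stated time of 1 h, tested at 10 uM (on this read-out higher numbers stand for more inhibition at the one concentration tested (going by the name of the read-out) and lower numbers for less inhibition), compound 1 gives 102%, the highest of the three numbers recorded here. Compound 2 `O=C(O)COc1ccncc1-c1ccc2ccccc2c1` replaces that side chain with carboxymethoxy, and in this assay compound 2 gives 16%; the step of a number 86 percentage points lower from compound 1 to compound 2 (beyond the scatter) is large and well beyond the scatter. Compound 3 `CNC(=O)/C=C/c1ccncc1-c1ccc2cccnc2c1` keeps the ethenyl amide but adds a methyl on the amide nitrogen and a nitrogen in the fused ring, and in this assay compound 3 gives 82%, lower than compound 1 by more than the scatter; since two things change at once, the two values alone are known for this pair.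

Compound 4 `CN1CCN(C(=O)/C=C/c2ccncc2-c2ccc3ccccc3c2)CC1` is compound 1 with 4-methylpiperazin-1-yl in place of amino on a carbonyl carbon. For the measured compounds named here, no measured step isolates this exact change. Going by the values given here, the only single step recorded, from compound 1 to compound 2, removes the whole ethenyl amide and is not a close guide, while compound 3 shows that an alkyl group on the amide nitrogen is compatible with strong inhibition. Compound 4 is therefore expected to stay near compound 1, with a modest downward step of a number 24 percentage points lower from compound 1 to compound 4 (beyond the scatter) estimated, and its value in this assay is estimated at 78%, in a range from 45% to 102%.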

Compound 4, a percentage reported as inhibition, at one concentration (the size of the read-out at that concentration, not a potency): 101%
Beside the measured number, compound 4's estimate is 23 percentage points below it; the measured number falls inside the stated range.
By their numbers in this assay, from the lowest: compound 2; then compound 3; then compounds 4 and 1 (each within the scatter of the next).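

In this assay, 4-methylpiperazin-1-yl in place of amino on the carbonyl carbon gives a number 1 percentage points lower from compound 1 to compound 4 (within the scatter), so this read-out does not separate the two compounds. This is a big change in size: a single nitrogen leaves and 7 heavy atoms enter, including a six-membered non-aromatic ring, while the hydrogen-bond donor of amino is lost. The inhibition in this assay therefore stays level without the small amino group and without a donor at this place, something the earlier compounds could not show, and no measurement available here explains this result.

Going by these compounds, whether other groups on this carbonyl carbon would do as well stays open, for example a hydroxyl, which would make the side chain a carboxylic acid, or a longer chain ending in an amine. On these data alone, a reading at one concentration gives only the size of the inhibition there, so whether compound 1 and compound 4 would also match in a full potency measurement remains unknown.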